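The compounds below may be only part of what the source reports. "The series", "measured", "known", "first", "only" and "open" are said of these compounds alone.

Measured so far in a physicochemical assay for solubility, read by HPLC, using the shake flask method, measured as kinetic solubility, with a stated time of 2 h, at pH 7.4; on this read-out lower numbers stand for lower solubility and higher numbers for higher solubility:
Compound 1, `Cc1cc(NCc2ccccn2)n2nc(C)c(-c3ccc(F)cc3)c2n1`, gives < 5000 nM, which is a limit of the assay and not a number.
Compound 2, `Cc1cc(Nc2ccccn2)n2nc(C)c(-c3ccccc3)c2n1`, gives < 5000 nM, again a limit.
Compound 3, `Cc1cc(NCc2ccccn2)n2ncc(-c3cccc(Cl)c3)c2n1`, gives < 5000 nM, again a limit.

Compound 2 thus stands at the limit of this assay, where, as the limit of < 5000 nM in this assay, at which 3 of the 3 values shown sit, every value shown sits, so nothing measured separates it from compound 1 or compound 3. The account follows the step from compound 2 to the unmeasured compound 4, `CCN1CCCC1CNc1cc(C)nc2c(-c3ccccc3)c(C)nn12`, which differs from compound 2 in one place.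

(1-ethylpyrrolidin-2-yl)methyl in place of pyridin-2-yl on a nitrogen on an aromatic ring

Among the measured compounds shown here, no step between two measured compounds is available, so nothing measured tells how large a change of this kind is in this assay. Because compound 2 sits at < 5000 nM, only a shift toward higher solubility could surface as a number, while a shift toward lower solubility would stay hidden under the same limit. The step expected from the change is one toward higher solubility, an at least 6.0-fold higher number from compound 2 to compound 4 (0.77 log units; beyond the scatter), held with low confidence. Compound 4 is therefore estimated at 30000 nM, with an expected range from 4000 nM to 200000 nM.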

Compound 4, solubility: 172000 nM
Compound 4: the middle estimate sits 5.7-fold (0.76 log units) below what was measured, within the range that was stated.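

In this assay, among the compounds shown here, the exchange of pyridin-2-yl for (1-ethylpyrrolidin-2-yl)methyl gives the first step that can be read: an at least 34-fold higher number from compound 2 to compound 4 (1.53 log units; beyond the scatter). Compound 4 is the only compound shown that stands clear of the limit, so this position is one where a single change can carry the read-out off it: the limit of < 5000 nM in this assay, at which 3 of the 4 values shown sit. The printed step is a lower bound and not a full size, and it comes from one exchange in which a six-membered aromatic ring leaves and a five-membered non-aromatic ring enters, so it does not show which part of the new group carries the shift.

As far as these compounds go, what remains open is whether the pyrrolidine ring, its ethyl group or its methyl link matters most, and whether a plain open-chain amine, such as a 2-(dimethylamino)ethyl group on that nitrogen, would give a step of similar size. From the compounds shown here alone, it also remains open whether the same exchange would move compound 1 or compound 3 off the limit, given their different substituents elsewhere on the shared core.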